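Fluorophenyl variation on a shared core: antiproliferation notes

The compounds below may be only part of what the source reports. "The series", "measured", "known", "first", "only" and "open" are said of these compounds alone.

Compound 1 `COc1cc(C2=NN(C(C)=O)C(c3cccc(F)c3)O2)cc(OC)c1OC` and compound 2 `COc1cc(C2=NN(C(C)=O)C(c3ccc(F)c(F)c3)O2)cc(OC)c1OC` share one core and differ only in the fluorine pattern of the aryl group on the saturated ring carbon. In a functional assay on BGC-823 cells (Homo sapiens) for antiproliferative activity, read by MTT assay, tested at 1 uM (a lower number here means a weaker effect, a higher number a stronger effect of the compound at the concentration tested), compound 1 gives 14.7%. In this assay compound 2 gives 18.3%. Within the data shown here, the one measured step between them, a number 3.6 percentage points higher from compound 1 to compound 2 (within the scatter), lies within the scatter, so compound 2 stands among the two measured compounds at a number that cannot be separated from that of compound 1.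

Compound 3 `COc1cc(C2=NN(C(C)=O)C(c3ccccc3F)O2)cc(OC)c1OC` is the next member. The change from compound 2 is 2-fluorophenyl in place of 3,4-difluorophenyl on a saturated ring carbon. Among the measured compounds shown here, the only measured step that bears on it is a number 3.6 percentage points higher from compound 1 to compound 2 (within the scatter), where fluoro in place of hydrogen on an aromatic carbon moved the read-out by an amount within the scatter. For the measured compounds named here, compound 3 carries a single fluorine, as compound 1 does, and the series holds no step that separates one fluorophenyl from another, so no move beyond the scatter is foreseen. The expected step for compound 3 is a number 2.3 percentage points lower from compound 2 to compound 3 (within the scatter) in this assay. Compound 3 is therefore estimated at 16%, with a range from 5% to 28%.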

Compound 3, a percentage reported as inhibition, at one concentration (the size of the read-out at that concentration, not a potency): 29.6%
Compound 3: the middle estimate sits 13.6 percentage points below what was measured, and the stated range ends below it.
By their numbers in this assay, from the lowest: compounds 1 and 2 (each within the scatter of the next); then compound 3.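

The aryl group on the saturated ring carbon is now shown to be a place where the read-out can move beyond the scatter in this assay: 2-fluorophenyl in place of 3,4-difluorophenyl gives a number 11.3 percentage points higher from compound 2 to compound 3 (beyond the scatter) and is the first such move in the series. The comparison between the two single-fluorine compounds is the cleaner one, as 2-fluorophenyl in place of 3-fluorophenyl leaves the number of fluorines unchanged and still gives a number 14.9 percentage points higher from compound 1 to compound 3 (beyond the scatter) in the same assay. Across compound 1, compound 2 and compound 3, the read-out therefore goes with the location of fluorine on the phenyl ring and not with the fluorine count, although three compounds are a narrow basis and no measurement shown here explains the difference.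

The compounds shown leave open whether the gain of compound 3 belongs to fluorine itself or would also appear with another group in its place on the phenyl ring, such as chloro, methoxy or an amine. They also leave open how an unsubstituted phenyl compares and whether the 2-fluorophenyl gain would hold if the acetyl group gave way to a longer acyl chain such as butanoyl.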